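Shortening the acyl chain toward acetyl

The source may report more compounds than this note shows. Statements on the series, on what has been measured and on what is new or still open speak of the compounds shown alone.

As far as these compounds go, three compounds carry the same shared core in which two aryl ethers are joined by a four-carbon linker, and one further compound is still open. Compound 1 `COC(=O)c1ccc(OCCCCOc2ccc(C(=O)CC3CCCC3)c(O)c2C)cc1`, the methyl ester, gives "not determined" (no result reported) in an assay on HEK293 cells for positive allosteric modulation of metabotropic glutamate receptor 2 (Rattus norvegicus), read by thallium flux, with a stated time of 2.5 min; on this read-out lower numbers stand for an effect already at smaller amounts and higher numbers for an effect only at larger amounts of compound. Compound 2 `Cc1c(OCCCCOc2cccc(C(=O)O)c2)ccc(C(=O)CC2CCCC2)c1O`, which keeps a cyclopentyl group on its ketone chain, gives 451 nM in this assay. Compound 3 `CCCC(=O)c1ccc(OCCCCOc2ccc(C(=O)O)cc2C)c(C)c1O`, with a propylcarbonyl group and a carboxylic acid on the other ring, gives 104 nM, the lowest of the two numbers, and its gap to compound 2 lies beyond the scatter. For the measured compounds named here, no pair of these measured compounds differs in only one place, so no single step can be read from them.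

Compound 4 `CC(=O)c1ccc(OCCCCOc2ccc(C(=O)O)cc2C)c(C)c1O` is compound 3 with hydrogen in place of ethyl on a saturated chain carbon bound to a carbonyl carbon, so that the propylcarbonyl group becomes an acetyl group. Nothing measured here shows what removing carbon from the ketone chain does on its own. Compound 4 is expected to give a somewhat higher number than compound 3, and the estimated step of a 2.9-fold higher number from compound 3 to compound 4 (0.46 log units; beyond the scatter) is anticipated to reach slightly beyond the scatter. Compound 4 is therefore estimated at 300 nM, with a range from 100 nM to 1200 nM.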

Compound 4, half-maximal effective concentration: 50 nM
Estimate against measurement, compound 4: 6.0-fold (0.78 log units) above, and the stated range ends above it.
By their numbers in this assay, from the lowest: compound 4; then compound 3; then compound 2.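

Hydrogen in place of ethyl on a saturated chain carbon bound to a carbonyl carbon, which turns the propylcarbonyl group into an acetyl group, gives the first step in this series that can be read on its own: a 2.1-fold lower number from compound 3 to compound 4 (0.32 log units; beyond the scatter) in this assay. For the compounds shown here, the step is modest, yet it shows that at this place on the shared core the two carbons of the ethyl group can leave without the number rising, and that the acetyl group of compound 4 carries the lowest number of the three measured so far. Nothing shown here gives a reason for this direction of change.

As far as these compounds go, whether the trend holds beyond this one pair stays open: a single step cannot tell how a hydrogen on the ketone carbonyl, a methoxy group or a cyclopropyl group in place of the methyl of the acetyl group would read. Compound 1 has no number and compound 2 differs from compound 3 in more than one place, so neither the methyl ester nor the cyclopentyl group can yet be judged on its own.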